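A few compounds are considered here, and "the series" means these few. Any claim that something is new, unique, unknown or untested is made for them only; others in the source may bear on it.

Compound 1, `Clc1ccc(Oc2cncc(C3=CC4CNCC(C3)C4)c2)cc1`: 40 nM
Compound 2, `C1=C(c2cncc(Oc3ccccc3)c2)CC2CNCC1C2`: 1.9 nM

Compound 2 gives the lowest of the two numbers in an in vitro assay on SH-SY5Y cells for displacement of a labelled ligand from Neuronal acetylcholine receptor; alpha3/beta4 (Homo sapiens); on this read-out higher numbers stand for weaker inhibition and lower numbers for stronger inhibition; its nearest neighbour is compound 1, and the step of a 21-fold lower number from compound 1 to compound 2 (1.32 log units; beyond the scatter) separates the two. Compound 3, `Clc1cccc(Oc2cncc(C3=CC4CNCC(C3)C4)c2)c1`, has not yet been measured. It differs from compound 2 by chloro in place of hydrogen on an aromatic carbon. Among the measured compounds shown here, the one measured step that bears on this change is a 21-fold lower number from compound 1 to compound 2 (1.32 log units; beyond the scatter), where removing a chloro from that same ring gave a large drop in the number, that is, a large gain in binding strength. Putting a chloro back onto that ring is therefore expected to raise the number again, and a clear step upward is expected for compound 3, a 5.3-fold higher number from compound 2 to compound 3 (0.72 log units; beyond the scatter). For the measured compounds named here, no measured compound carries a chloro placed as in compound 3, so the size of this step is uncertain. Compound 3 is expected to give 10 nM, with a range from 3 nM to 40 nM.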

Compound 3, inhibition constant: 22 nM
Estimate against measurement, compound 3: 2.2-fold (0.34 log units) below; low and high end bracket the measured number.
By their numbers in this assay, from the lowest: compound 2; then compounds 3 and 1 (each within the scatter of the next).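

In this assay, a chloro meta to a large group on the phenyl ring also weakens binding, with a 12-fold higher number from compound 2 to compound 3 (1.06 log units; beyond the scatter), so the earlier penalty is not confined to the chloro of compound 1. Changing 4-chlorophenyl to 3-chlorophenyl gives a 1.8-fold lower number from compound 1 to compound 3 (0.26 log units; within the scatter), which leaves compound 1 and compound 3 indistinguishable. Across these three compounds, what separates the numbers is whether the ring carries a chloro at all, not which of these two places holds it, and none of the three goes against this.

Nothing available explains why a chloro on this ring gives a higher number. Whether this penalty is specific to chloro remains open, as the compounds shown do not reveal how a fluoro, a methyl or a methoxy at either place would compare with the hydrogen of compound 2.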